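The source may hold more compounds than are shown below. What is called first, only, known or untested is meant among the compounds shown, and "the series" means these compounds.

Measured in an assay for inhibition of Polyunsaturated fatty acid 5-lipoxygenase (Homo sapiens), read by spectrophotometry, tested at 10 uM, in the presence of a further agent that is not named here; on this read-out higher numbers stand for more inhibition at the one concentration tested (going by the name of the read-out) and lower numbers for less inhibition:
compound 1 `Cc1nc(NC(=O)c2ccccc2)sc1C(=O)/C=C/c1ccc(Br)cc1` gives 52.3%
compound 2 `COc1ccc(/C=C/C(=O)c2sc(NC(=O)c3ccccc3)nc2C)cc1` gives 58.8%
compound 3 `Cc1ccc(/C=C/C(=O)c2sc(NC(=O)c3ccccc3)nc2C)cc1` gives 75.1%

Compound 3 stands highest of the three, and both steps towards it lie beyond the scatter: a number 22.8 percentage points higher from compound 1 to compound 3 (beyond the scatter) and a number 16.3 percentage points higher from compound 2 to compound 3 (beyond the scatter). The step of a number 6.5 percentage points higher from compound 1 to compound 2 (within the scatter) lies within the scatter. Compound 4 `Cc1nc(NC(=O)c2ccccc2)sc1C(=O)/C=C/c1ccc(N(C)C)cc1` carries dimethylamino in place of methyl on an aromatic carbon. Among the compounds with values here, no measured pair shows this change; the two steps into compound 3 only show that methyl gives modestly more inhibition than bromo or methoxy on this aromatic carbon, so leaving methyl for another group is expected to cost some inhibition, though a step within the scatter cannot be ruled out. The expected step is a number 13.1 percentage points lower from compound 3 to compound 4 (beyond the scatter). Compound 4 is therefore estimated at 62%, with a range from 45% to 78%.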

Compound 4, a percentage reported as inhibition, at one concentration (the size of the read-out at that concentration, not a potency): 88.2%
For compound 4 the middle estimate is 26.2 percentage points below the measured one; the measured number lies above the stated range.
By their numbers in this assay, from the lowest: compounds 1 and 2 (each within the scatter of the next); then compound 3; then compound 4.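

In this assay methyl is not the upper end at this aromatic carbon: dimethylamino gives a number 13.1 percentage points higher from compound 3 to compound 4 (beyond the scatter), so leaving methyl brings a gain, not a loss. The same group also gives a number 29.4 percentage points higher from compound 2 to compound 4 (beyond the scatter) and a number 35.9 percentage points higher from compound 1 to compound 4 (beyond the scatter), which places compound 4 highest of the four, with all its steps beyond the scatter. Nothing available explains this gain.

Open, going by these compounds, is whether a primary amine or diethylamino on this carbon would hold this level. Also open, on these data alone, is whether a carboxylic acid there would lower it.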